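Pyrazole amide series: chloro removal on the benzamide ring

A few compounds are considered here, and "the series" means these few. Any claim that something is new, unique, unknown or untested is made for them only; others in the source may bear on it.

Measured compounds:
compound 1 `O=C(Nc1cccc(-n2cc(-c3ccncc3)c(-c3ccc(Cl)c(O)c3)n2)c1)Nc1ccc(Cl)c(Cl)c1`: 1060 nM
compound 2 `COc1cc(-c2nn(-c3cccc(NC(=O)c4ccc(Cl)c(C(F)(F)F)c4)c3)cc2-c2ccncc2)ccc1Cl`: 2240 nM

In a functional assay on MCF7 cells (Homo sapiens) for inhibition, read by sulforhodamine B assay, with a stated time of 48 h (on this read-out higher numbers stand for weaker inhibition of growth and lower numbers for stronger inhibition of growth), compound 1 gives 1060 nM. In the same assay compound 2 gives 2240 nM. Compound 2 thus carries the higher of the two numbers, and the gap to compound 1 lies beyond the usual scatter. Within the data shown here, only these two numbers exist, and the two compounds differ in more than one place, so no single-change step between measured compounds is available to lean on.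

Compound 3 `COc1cc(-c2nn(-c3cccc(NC(=O)c4cccc(C(F)(F)F)c4)c3)cc2-c2ccncc2)ccc1Cl` is the next candidate in this assay. It differs from compound 2 by hydrogen in place of chloro on an aromatic carbon. Among the measured compounds shown here, no measured pair covers this change, so the expectation rests on the structural change alone. The expectation for compound 3 is a moderate move toward weaker growth inhibition, a step of a 1.8-fold higher number from compound 2 to compound 3 (0.25 log units; within the scatter) in this assay, since nothing in the data suggests a gain from the loss of the chloro. The estimate for compound 3 is 4000 nM, with a range from 1500 nM to 12000 nM.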

Compound 3, concentration for 50% growth inhibition: 1430 nM
Estimate against measurement, compound 3: 2.8-fold (0.45 log units) above; the measured number lies below the stated range.
By their numbers in this assay, from the lowest: compounds 1, 3 and 2 (each within the scatter of the next, the first and the last beyond it).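

Replacing chloro with hydrogen, which turns the 4-chloro-3-(trifluoromethyl)phenyl group into 3-(trifluoromethyl)phenyl, gives in this assay a 1.6-fold lower number from compound 2 to compound 3 (0.19 log units; within the scatter) and is the one place in the compounds shown where a single change can be read. At this position, ortho to a trifluoromethyl group and para to a large group, compound 2 and compound 3 cannot be told apart, so the chloro is not required for a number of this size in this pair. No measurement bears on why the step is this small.

From the compounds shown here alone, whether an amine or a carboxylic acid on the same aromatic carbon would move the number beyond the scatter stays open, as does the effect on the number of replacing the trifluoromethyl group on this ring. Among these compounds, compound 1 differs from both compound 2 and compound 3 in more than one place, so no step to it can be read, and the parts of the structure that separate it from them remain unresolved.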